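Swapping chloro for cyano on the benzoyl piperazine

A few compounds are considered here, and "the series" means these few. Any claim that something is new, unique, unknown or untested is made for them only; others in the source may bear on it.

Measured compounds:
- compound 1 `Cc1cccc(Cn2c(OC3CCN(C(=O)c4ccco4)CC3)nc3ccccc32)c1`: 68.3%
- compound 2 `O=C(C1CC1)N1CCN(Cc2nc3ccccc3n2Cc2ccccc2C(F)(F)F)CC1`: 56.3%
- compound 3 `Cc1cccc(Cn2c(CN3CCN(C(=O)c4ccc(Cl)cc4)CC3)nc3ccccc32)c1`: 23.2%

Of the compounds shown here, three share the same benzimidazole-type core and have been read in an assay on isolated protein for inhibition of aldehyde dehydrogenase 1A1 (Homo sapiens), read by spectrophotometry, tested at 10 uM; on this read-out higher numbers stand for more inhibition at the one concentration tested (going by the name of the read-out) and lower numbers for less inhibition. Compound 1 gives 68.3%, compound 2 gives 56.3%, and compound 3 gives 23.2%. Compound 3 stands lowest of the three; its nearest neighbour, compound 2, lies beyond the scatter above it, and compound 1 lies further still.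

The next compound, compound 4 `Cc1cccc(Cn2c(CN3CCN(C(=O)c4ccc(C#N)cc4)CC3)nc3ccccc32)c1`, keeps the whole skeleton of compound 3 and changes one group on the benzoyl ring: cyano in place of chloro on an aromatic carbon. Among the compounds with values here, no two measured compounds differ in just this way, so the data give no direct steer on what exchanging chloro for cyano on an aromatic carbon of a six-membered aromatic ring of carbon only does in this assay.

With nothing in the measured set to push the expectation either way, compound 4 is expected to stay close to compound 3, with a step of a number 1.2 percentage points lower from compound 3 to compound 4 (within the scatter) that is not expected to exceed the scatter. Compound 4 is therefore estimated at 22%, in a range from 5% to 45%.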

Compound 4, a percentage reported as inhibition, at one concentration (the size of the read-out at that concentration, not a potency): 20.8%
Beside the measured number, compound 4's estimate is 1.2 percentage points above it; measured number inside the range.
By their numbers in this assay, from the lowest: compounds 4 and 3 (each within the scatter of the next); then compound 2; then compound 1.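

In this assay, within the data shown here, exchanging chloro for cyano on the aromatic carbon para to a large group gives the first single-place comparison in the set, a step of a number 2.4 percentage points lower from compound 3 to compound 4 (within the scatter). At this position, then, going from 4-chlorophenyl to 4-cyanophenyl leaves the reading unresolved from that of the chloro compound, even though cyano brings a hydrogen-bond acceptor and a triple bond that chloro lacks. Nothing available accounts for this outcome.

Going by these compounds, whether an amine, a carboxylic acid or a methoxy group on the same carbon would read any differently remains open. Compound 1 and compound 2 each differ from compound 3 and compound 4 in more than one place, so the steps to them cannot be read, and what separates their numbers stays unassigned.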